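A few compounds are considered here, and "the series" means these few. Any claim that something is new, unique, unknown or untested is made for them only; others in the source may bear on it.

Working notes on the series. The shared core carries an acylhydrazone urea on a diaryl pyrimidine; compound 1 `COc1ccc(-c2cc(-c3ccc(F)cc3)nc(NC(=O)N/N=C\c3cccc(Cl)c3)n2)cc1OC` bears a dimethoxyphenyl group and a chlorobenzylidene, compound 2 `C/C(=N/NC(=O)Nc1nc(-c2ccc(F)cc2)cc(-c2ccc([N+](=O)[O-])cc2)n1)c1ccc(C)cc1` a nitrophenyl group and a methylphenyl ketone hydrazone, and compound 3 `C/C(=N/NC(=O)Nc1nc(-c2ccc(C)cc2)cc(-c2ccc(F)cc2)n1)c1ccc(Cl)cc1` a methylphenyl group and a chlorophenyl ketone hydrazone. In a functional assay on the whole organism (strain Albino) with Mus musculus as the target, with a stated time of 4 h (a lower number here means that less compound is needed, a higher number that more compound is needed for the effect), compound 1 gives 300 mg/kg, compound 2 gives 300 mg/kg and compound 3 gives 100 mg/kg. Compound 2 stands level with compound 1 at the digits shown, the two together at the top of the three numbers; compound 3 sits beyond the scatter below them.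

Compound 4 `COc1ccc(-c2cc(-c3ccc(F)cc3)nc(NC(=O)N/N=C(/C)c3ccc(C)cc3)n2)cc1` is the next compound for this assay; it differs from compound 2 by methoxy in place of nitro on an aromatic carbon, on an aromatic carbon of a six-membered carbon ring, para to a large group. Among the measured compounds shown here, no measured pair in this set isolates this change, and compound 1 and compound 3 differ from compound 2 in more than one place, so their values give no clean step. Within the numbers shown, no change beyond the scatter is expected from the nitro to methoxy swap in this assay, with a lower value slightly favoured only because compound 3 gives 100 mg/kg without a nitro group. The expected step from compound 2 to compound 4 is a 1.2-fold lower number from compound 2 to compound 4 (0.08 log units; within the scatter). For compound 4 the estimate in this assay is 250 mg/kg, within a range from 100 mg/kg to 500 mg/kg.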

Compound 4, dose for half-maximal effect: 100 mg/kg
For compound 4 the middle estimate is 2.5-fold (0.40 log units) above the measured one; the range from low to high includes it.
By their numbers in this assay, from the lowest: compounds 3 and 4 (each within the scatter of the next); then compounds 1 and 2 (each within the scatter of the next).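

In this assay, among the compounds shown here, the change from 4-nitrophenyl to 4-methoxyphenyl gives a 3.0-fold lower number from compound 2 to compound 4 (0.48 log units; beyond the scatter) with the rest of the structure unchanged, the first step that can be read at one place. This aromatic carbon, para to a large group, therefore responds to the group it carries, which compound 1 and compound 3 could not show, as each differs from compound 2 in more than one place. No measurement shown here accounts for the step.

One pair cannot separate the loss of nitro from the gain of methoxy, and an amine, a hydroxyl or a plain hydrogen at this place would help to tell the two apart. On these data alone, whether the same swap gives a similar step with other groups elsewhere on the shared core remains open.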